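The source may report more compounds than this note shows. Statements on the series, on what has been measured and on what is new or still open speak of the compounds shown alone.

In an ADME assay on microsomes from liver (Mus musculus) for metabolic stability, read by LC-MS, with NADPH named in the record, with a stated time of 60 min, tested at 1 uM, in the absence of a further agent (a lower number here means that less of the compound is left, a higher number that more of the compound is left), compound 1 (`COc1ccc(-n2c(C)nc3c(N4CC[C@@H](NC(C)=O)C4)nc(C)nc32)cc1OC`) gives > 95% as a limit of the assay, not as a number. Compound 2 (`CC(=O)N[C@@H]1CCN(c2cc(C)nn3c(-c4nccs4)c(C)nc23)C1`) gives > 95% as a limit too. Compound 3 (`CCCCCC(=O)N[C@@H]1CCN(c2cc(C)nn3c(-c4ccc(OC)c(OC)c4)c(C)nc23)C1`), the starting point here, likewise gives > 95% as a limit, with no exact figure. For the measured compounds named here, all the measured compounds thus share one position (the limit of > 95% in this assay, at which 3 of the 3 values shown sit) and no measured pair shows what a single structural change does.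

Compound 4 (`COc1ccc(-c2c(C)nc3c(N4CC[C@@H](NS(C)(=O)=O)C4)cc(C)nn23)cc1OC`) has not been measured yet. It carries methylsulfonyl in place of pentylcarbonyl on an amine nitrogen and the rest of the structure stays the same. Going by the values given here, with no measured step to go by, the expectation rests on compound 3 alone, whose > 95% is a limit. The estimated step (a number at least 1 percentage points lower from compound 3 to compound 4 (that floor lies within the scatter)) in this assay is expected to stay within the usual scatter, and any movement that does appear is expected to be downward. Compound 4 is estimated at 94% (expected range 80% to 100%).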

Compound 4, percent of the compound remaining: > 95%
Compound 4: a limit, no number (the forecaster's own chance of this, stated with the estimate: 55%); middle value at least 1 percentage points from the limit.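

No step from compound 3 to compound 4 can be read in this assay, because both compounds stop at a limit rather than a number: the limit of > 95% in this assay, at which 4 of the 4 values shown sit.

The compounds shown leave open how much methylsulfonyl in place of pentylcarbonyl, or any other single change, alters the percent of compound remaining.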